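From fluoro to chloro at the assay limit

The source may report more compounds than this note shows. Statements on the series, on what has been measured and on what is new or still open speak of the compounds shown alone.

Compound 1 `CN(C)c1ncc(/C=C/c2c(F)cccc2Cl)cn1` gives > 200 nM as a limit
Compound 2 `CNc1ncc(/C=C/c2c(F)cccc2Cl)cn1` gives > 200 nM as a limit

In a functional assay on LS174T cells (Homo sapiens) for antiproliferative activity (on this read-out higher numbers stand for weaker inhibition and lower numbers for stronger inhibition), compound 1 gives > 200 nM and this is a limit, not a number. Compound 2 gives > 200 nM and this too is a limit. Compound 1 thus stands at the limit of > 200 nM in this assay, at which 2 of the 2 values shown sit, and no finer placing is possible. Compound 3 `CN(C)c1ncc(/C=C/c2c(Cl)cccc2Cl)cn1` has chloro in place of fluoro on an aromatic carbon of the core of compound 1, and the counted change is chloro in place of fluoro on an aromatic carbon in full. Going by the values given here, the only measured step, a step that the two limits leave unreadable from compound 1 to compound 2, lies at a nitrogen and gives no readable size. No step beyond the scatter is therefore expected in this assay and no direction is favoured, so the expected step is a step that the limit leaves unreadable from compound 1 to compound 3 at most loosely. Compound 3 is expected at 250 nM with an estimated range of 60 nM to 1000 nM when it is measured.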

Compound 3, half-maximal inhibitory concentration: > 200 nM
Compound 3: no number, only a limit; the forecaster's own chance of this, stated with the estimate: 55%; the middle value lies beyond the limit too.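

In this assay compound 3 gives > 200 nM as a limit and not a number, and compound 1 is held at a limit too, so no step between them can be read: the limit of > 200 nM in this assay, at which 3 of the 3 values shown sit.

The compounds shown leave open how far each lies from that limit and what chloro in place of fluoro on an aromatic carbon does in this assay at all.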